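Amide series: amine tail change from compound 2 to compound 3

The compounds below may be only part of what the source reports. "The series", "measured", "known", "first", "only" and "open" are said of these compounds alone.

Measured so far:
compound 1 `COc1cc2c(Oc3ccc(NC(=O)c4cc(-c5cccc(Cl)c5)nc5ccccc45)cc3F)ccnc2cc1OCCCN1CCC(C)CC1`: 100 nM
compound 2 `COc1cc2c(Oc3ccc(NC(=O)c4cc(-c5ccc(C)cc5)nc5ccccc45)cc3F)ccnc2cc1OCCCN1CCC(C)CC1`: 3150 nM

In a functional assay on HT-29 cells (Homo sapiens) for cytotoxicity, read by MTT assay, with a stated time of 72 h (on this read-out higher numbers stand for weaker inhibition and lower numbers for stronger inhibition), compound 1 gives 100 nM and compound 2 gives 3150 nM. For the measured compounds named here, compound 2 stands highest of the two numbers; its only neighbour is compound 1, with a 32-fold higher number from compound 1 to compound 2 (1.50 log units; beyond the scatter). Compound 3 `COc1cc2c(Oc3ccc(NC(=O)c4cc(-c5ccc(C)cc5)nc5ccccc45)cc3F)ccnc2cc1OCCCN1CCCC1` differs from compound 2 by pyrrolidin-1-yl in place of 4-methylpiperidin-1-yl on a saturated chain carbon, three bonds along the chain from an oxygen on an aromatic ring. Going by the values given here, no measured step bears on this change: the single step, a 32-fold higher number from compound 1 to compound 2 (1.50 log units; beyond the scatter), concerns the aryl group, not the chain amine. No step beyond the scatter is therefore expected in this assay. Compound 3 is estimated at 3150 nM, between 1000 nM and 10000 nM, which means an expected step of no change at the digits printed from compound 2 to compound 3 (within the scatter).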

Compound 3, half-maximal inhibitory concentration: 850 nM
Estimate against measurement, compound 3: 3.7-fold (0.57 log units) above; the whole stated range lies above it.
By their numbers in this assay, from the lowest: compound 1; then compound 3; then compound 2.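

In this assay, the amine on the chain is shown to matter: 3-(pyrrolidin-1-yl)propyl in place of 3-(4-methylpiperidin-1-yl)propyl gives a 3.7-fold lower number from compound 2 to compound 3 (0.57 log units; beyond the scatter). This step is smaller than the aryl step, a 32-fold higher number from compound 1 to compound 2 (1.50 log units; beyond the scatter), but it shows that the number responds to more than one part of the molecule. No available evidence bears on why the smaller amine ring gives the lower number.

Going by these compounds, whether the amine step carries over to the 3-chlorophenyl group of compound 1 remains open. Also open, on these data alone, is how a morpholine ring, a dimethylamino group or a longer chain would read at this position.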